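Naphthalen-2-yl sulfonate ester in a bridged bisphenol series

The source may report more compounds than this note shows. Statements on the series, on what has been measured and on what is new or still open speak of the compounds shown alone.

Measured compounds:
- compound 1 `O=C(O)CCCCCCC(=O)Nc1ccc(C2=C(c3ccc(O)cc3)C3CC(S(=O)(=O)Oc4ccccc4C(F)(F)F)C2O3)cc1`: 26100 nM
- compound 2 `O=C(O)CCCCCCC(=O)Nc1cccc(OS(=O)(=O)C2CC3OC2C(c2ccc(O)cc2)=C3c2ccc(O)cc2)c1`: > 100000 nM
- compound 3 `O=C(O)CCCCCCC(=O)Nc1ccc(OS(=O)(=O)C2CC3OC2C(c2ccc(O)cc2)=C3c2ccc(O)cc2)cc1`: 19100 nM

In a functional assay on MCF7 cells (Homo sapiens) for inhibition, read by MTT assay, with a stated time of 72 h (a higher number here means a weaker inhibitor, a lower number a stronger inhibitor), compound 1 gives 26100 nM, the higher of the two numbers available. Compound 3 gives 19100 nM, which sits within the scatter of the number for compound 1, so the two cannot be ranked against each other. For compound 2 the assay reports only a limit, > 100000 nM; this is the case described by the limit of > 100000 nM in this assay, at which 1 of the 3 values shown sits.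

Compound 4 `O=C(O)CCCCCCC(=O)Nc1ccc(C2=C(c3ccc(O)cc3)C3CC(S(=O)(=O)Oc4ccc5ccccc5c4)C2O3)cc1` is not yet measured. It differs from compound 1 in one place: naphthalen-2-yl in place of 2-(trifluoromethyl)phenyl on an oxygen. For the measured compounds named here, no measured pair in this set carries a change of this kind, so the size of the step rests only on the shared core and the hydroxyphenyl groups kept in both compounds. No step beyond the scatter is expected in this assay. The step from compound 1 to compound 4 is estimated as a 1.2-fold lower number from compound 1 to compound 4 (0.07 log units; within the scatter). Compound 4 is thus expected to give 22000 nM, with a range from 8000 nM to 70000 nM.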

Compound 4, half-maximal inhibitory concentration: 18900 nM
Estimate against measurement, compound 4: 1.2-fold (0.07 log units) above; low and high end bracket the measured number.
By their numbers in this assay, from the lowest: compounds 4, 3 and 1 (each within the scatter of the next). At a limit, above all of these: compound 2.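

In this assay, for the compounds shown here, the exchange of 2-(trifluoromethyl)phenyl for naphthalen-2-yl on the oxygen bound to the sulfonyl sulfur reads as a 1.4-fold lower number from compound 1 to compound 4 (0.14 log units; within the scatter), the first one-place step in this set. At this position, then, a group with 2 six-membered aromatic rings of carbon only and no fluorine is not separated from a group with one such ring and 3 fluorine atoms. The measurements shown offer no basis for explaining this outcome.

Open, as far as these compounds go, is whether a phenyl ring bearing an amine or a carboxylic acid, or a small alkyl group such as methyl, on this oxygen would move the number beyond the scatter. Also open, from the compounds shown here alone, is whether any change at this position can do so while the rest of compound 4 stays the same.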